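Chloro in Place of Trifluoromethyl: Expectation for Compound 4

This account rests on a few compounds, and the source may have more. Where it says the series, first, only, none or still open, it means among the compounds named here.

Of the compounds shown here, three have been measured in an assay on MDA-MB-231 cells for binding affinity to C-X-C chemokine receptor type 4 (Homo sapiens), read by fluorescence and microscopy, with stated times of 10 min and 30 min; a higher number here means that more compound is needed for the effect, a lower number that less compound is needed. Compound 1 `CCN(CC)Cc1ccc(S(=O)(=O)NCc2ccc(CNC(=O)c3ccc(F)cc3)cc2)cc1` gives 1 nM in this assay, compound 2 `O=C(NCc1ccc(CNS(=O)(=O)c2cccc(C(F)(F)F)c2)cc1)c1ccc(F)cc1` gives 100 nM, and compound 3 `Cc1ccc(S(=O)(=O)NCc2ccc(CNC(=O)c3ccc(F)cn3)cc2)cc1` gives 1000 nM. Compound 2 thus stands second highest of the three numbers, separated from compound 1 below it and from compound 3 above it by gaps that lie beyond the usual scatter. Compound 4 `O=C(NCc1ccc(CNS(=O)(=O)c2cccc(Cl)c2)cc1)c1ccc(F)cc1` has not yet been measured. It differs from compound 2 by chloro in place of trifluoromethyl on an aromatic carbon; cut one bond further out, 3-(trifluoromethyl)phenyl becomes 3-chlorophenyl. Among the measured compounds shown here, no pair of measured compounds differs in a single place, so no measured step guides this change. Compound 4 is expected to give 100 nM in this assay, within a range from 30 nM to 300 nM. The estimate implies a step of no change at the digits printed from compound 2 to compound 4 (within the scatter), expected to stay within the usual scatter.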

Compound 4, effective concentration (reported as EC, without a stated level of effect): 1 nM
The estimate for compound 4 lay 100-fold (2.00 log units) above the measured number, outside the stated range (below it).
By their numbers in this assay, from the lowest: compounds 1 and 4 (each within the scatter of the next); then compound 2; then compound 3.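

In this assay, chloro in place of trifluoromethyl on this aromatic carbon, meta to a large group, gives a 100-fold lower number from compound 2 to compound 4 (2.00 log units; beyond the scatter), a large step. Among the compounds shown here, this shows that the number responds strongly to the group held at this position, which the earlier compounds could not show, as none of them differed in a single place. No measurement shown here accounts for the step. On these data alone, whether bromo, methyl or an amine at this carbon would match chloro remains open. So does whether the same exchange would give a similar step on another core.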